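This account rests on a few compounds, and the source may have more. Where it says the series, first, only, none or still open, it means among the compounds named here.

Measured in an ADME assay on HepG2 2.2.15 cells (Homo sapiens) for cytotoxicity; on this read-out lower numbers stand for higher toxicity in this test and higher numbers for lower toxicity in this test:
- compound 1 `CCCC(=O)OCCc1c(-c2ccccc2Cl)c2cc(Cl)ccc2[nH]c1=O`: 52000 nM
- compound 2 `O=C(OCCc1c(-c2ccccc2Cl)c2cc(Cl)ccc2[nH]c1=O)C1CCCCC1`: 38000 nM

Going by the values given here, compound 2 stands level with compound 1, the only other measured compound, since their two values lie within the scatter of each other. Compound 3 `O=C(OCCc1c(-c2ccccc2Cl)c2cc(Cl)ccc2[nH]c1=O)c1cccs1` keeps the shared core and changes only the group on the carbonyl carbon, with thiophen-2-yl in place of cyclohexyl on a carbonyl carbon. Among the compounds with values here, the one measured step at this place, a 1.4-fold lower number from compound 1 to compound 2 (0.14 log units; within the scatter), put cyclohexyl in place of propyl and stayed within the scatter. Within the data shown here, it is a single step, and no aromatic ring has yet been measured on this carbonyl carbon, so it is only a weak guide. No step beyond the scatter is therefore expected in this assay, and no direction can be named. The expected change is a 1.1-fold higher number from compound 2 to compound 3 (0.02 log units; within the scatter). For compound 3 the estimated value is 40000 nM, with an expected range from 18000 nM to 85000 nM.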

Compound 3, half-maximal cytotoxic concentration: > 1700000 nM
Compound 3: a limit, no number; the forecaster's own chance of this, stated with the estimate: 15%; middle value at least 42-fold (1.62 log units) from the limit.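

The group on the carbonyl carbon can matter a great deal in this assay: the earlier swap of propyl for cyclohexyl stayed within the scatter, yet thiophen-2-yl gives an at least 44-fold higher number from compound 2 to compound 3 (1.65 log units; beyond the scatter) and an at least 32-fold higher number from compound 1 to compound 3 (1.51 log units; beyond the scatter). This place therefore does not tolerate every change equally, and with a five-membered aromatic ring holding one hetero atom there, the read-out moves far towards lower toxicity in this test. The result for compound 3 is a limit of the assay and not a number, so the full size of both steps stays unknown: the limit of > 1700000 nM in this assay, at which 1 of the 3 values shown sits.

Only one aromatic ring appears at this place among the compounds shown, so it stays open whether the shift belongs to aromatic rings in general or to thiophen-2-yl itself. A phenyl group, which has no sulfur, or a pyridine ring on the same carbonyl carbon would help separate these two readings.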